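Pyridin-2-yl in Place of Chlorophenyl: An Expected Value

This account rests on a few compounds, and the source may have more. Where it says the series, first, only, none or still open, it means among the compounds named here.

The three measured compounds in an assay on microsomes from brain for inhibition of Fatty-acid amide hydrolase 1 (Rattus norvegicus), read by fluorescence and HPLC, with a stated time of 60 min; on this read-out higher numbers stand for weaker inhibition and lower numbers for stronger inhibition:

- compound 1 `CCCCCCCCc1ccc(OCC(=O)Cn2nnc(-c3ccccc3)n2)cc1` gives 24 nM
- compound 2 `CCCCCCCCc1ccc(OCC(=O)Cn2nnc(-c3ccccc3Cl)n2)cc1` gives 32 nM
- compound 3 `CCCCCCCCc1ccc(OCC(=O)Cn2nnc(-c3cccc(C(=O)OC)c3)n2)cc1` gives 34 nM

Compound 2 gives the second highest of the three numbers and lies within the scatter of both neighbours: a 1.3-fold higher number from compound 1 to compound 2 (0.12 log units; within the scatter); a 1.1-fold higher number from compound 2 to compound 3 (0.03 log units; within the scatter). Compound 4 `CCCCCCCCc1ccc(OCC(=O)Cn2nnc(-c3ccccn3)n2)cc1` differs from compound 2 in one place: pyridin-2-yl in place of 2-chlorophenyl on an aromatic carbon. Among the compounds with values here, the steps that bear on this are the three changes of the ring attached to the shared core, a 1.3-fold higher number from compound 1 to compound 2 (0.12 log units; within the scatter), a 1.4-fold higher number from compound 1 to compound 3 (0.15 log units; within the scatter) and a 1.1-fold higher number from compound 2 to compound 3 (0.03 log units; within the scatter), all of which stayed within the scatter; none of the three compounds goes against this. Exchanging one six-membered aromatic ring for another is therefore expected to leave this assay essentially unchanged, with a 1.1-fold lower number from compound 2 to compound 4 (0.03 log units; within the scatter) as the estimated step. For compound 4 the value in this assay is estimated at 30 nM, with an expected range from 12 nM to 75 nM.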

Compound 4, half-maximal inhibitory concentration: 18 nM
Compound 4: middle estimate off by 1.7-fold (0.22 log units), on the high side; the measured number falls inside the stated range.
By their numbers in this assay, from the lowest: compounds 4, 1, 2 and 3 (each within the scatter of the next).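

In this assay, the aromatic carbon of the five-membered aromatic ring with 4 nitrogen now carries a six-membered aromatic ring with 1 hetero atom and 1 hydrogen-bond acceptor, and all three new steps stay within the scatter: a 1.3-fold lower number from compound 1 to compound 4 (0.12 log units; within the scatter), a 1.8-fold lower number from compound 2 to compound 4 (0.25 log units; within the scatter) and a 1.9-fold lower number from compound 3 to compound 4 (0.28 log units; within the scatter). The earlier compounds shown here had only rings of carbon at this position, so pyridin-2-yl extends the range of rings that show no step beyond the scatter, although the steps from compound 2 and compound 3 are the largest yet seen here. Nothing presented gives a reason for the size of these steps.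

The compounds shown leave open whether pyridin-3-yl or pyridin-4-yl would behave like pyridin-2-yl. They also leave open whether an amine or a carboxylic acid on the ring would stay within the scatter.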